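This account rests on a few compounds, and the source may have more. Where it says the series, first, only, none or still open, it means among the compounds named here.

Measured so far:
Compound 1 `O=C(Nc1cccc(-c2oc3cc(-c4ccc(F)cc4)ccc3c(=O)c2O)c1)c1ccc(C(F)(F)F)cc1`: 19400 nM
Compound 2 `COc1cccc(C(=O)Nc2cccc(-c3oc4cc(-c5ccc(F)cc5)ccc4c(=O)c3O)c2)c1`: 10800 nM

Both numbers come from a functional assay on A549 cells (Homo sapiens) for antiproliferative activity, read by CCK-8 assay, with a stated time of 72 h; on this read-out lower numbers stand for stronger inhibition and higher numbers for weaker inhibition. Among the compounds with values here, compound 2 shows the smaller of the two, but the only measured step, a 1.8-fold lower number from compound 1 to compound 2 (0.25 log units; within the scatter), stays within the scatter, so the two amide substituents are not separated. Compound 3 `O=C(Nc1cccc(-c2oc3cc(-c4ccc(F)cc4)ccc3c(=O)c2O)c1)c1ccc(Br)cc1F` carries 4-bromo-2-fluorophenyl in place of 3-methoxyphenyl on a carbonyl carbon. That single step bears on it, exchanging one aryl on the same carbonyl carbon for another without moving the number beyond the scatter. Compound 1, bearing 4-(trifluoromethyl)phenyl there, gives 19400 nM. For compound 3 no step beyond the scatter is expected in this assay, estimated at 14000 nM with range 6000 nM to 35000 nM. This estimate means a 1.3-fold higher number from compound 2 to compound 3 (0.11 log units; within the scatter).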

Compound 3, half-maximal inhibitory concentration: 46100 nM
Beside the measured number, compound 3's estimate is 3.3-fold (0.52 log units) below it; measured number outside the range, above it.
By their numbers in this assay, from the lowest: compounds 2 and 1 (each within the scatter of the next); then compound 3.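

In this assay the aryl group on the carbonyl carbon can now be seen to matter: the change to 4-bromo-2-fluorophenyl gives a 4.3-fold higher number from compound 2 to compound 3 (0.63 log units; beyond the scatter) and a 2.4-fold higher number from compound 1 to compound 3 (0.38 log units; beyond the scatter) and so yields weaker inhibition than either earlier aryl group. The earlier pair alone showed no separation at this position. No measurement here accounts for the weakening.
The compounds shown leave open whether the bromine or the fluorine carries this change, since the two appear only together. Also open, on these data alone, is how an aryl group bearing an amine or a carboxylic acid would read at this position.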